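Swapping the aryl group on the amide nitrogen

A few compounds are considered here, and "the series" means these few. Any claim that something is new, unique, unknown or untested is made for them only; others in the source may bear on it.

Measured compounds:
compound 1 `Cc1ccc(NC(=O)COc2ccc3cc(/C=C4/SC(=O)NC4=O)ccc3c2)cc1`: 1700 nM
compound 2 `O=C(COc1ccc2cc(/C=C3/SC(=O)NC3=O)ccc2c1)Nc1ccc(Br)cc1F`: 1900 nM
compound 3 `O=C(COc1ccc2cc(/C=C3/SC(=O)NC3=O)ccc2c1)Nc1cccc(C(F)(F)F)c1`: 2500 nM

In an assay on isolated protein for inhibition of histone deacetylase 4 (Homo sapiens), with a stated time of 1 h (on this read-out lower numbers stand for stronger inhibition and higher numbers for weaker inhibition), compound 3 stands highest of the three numbers, yet the steps of a 1.5-fold higher number from compound 1 to compound 3 (0.17 log units; within the scatter) and a 1.3-fold higher number from compound 2 to compound 3 (0.12 log units; within the scatter) both lie within the usual scatter, as does a 1.1-fold higher number from compound 1 to compound 2 (0.05 log units; within the scatter). Compound 4 `O=C(COc1ccc2cc(/C=C3/SC(=O)NC3=O)ccc2c1)Nc1ccc(F)cc1` differs from compound 3 by 4-fluorophenyl in place of 3-(trifluoromethyl)phenyl on an amide-type nitrogen. Every measured step exchanges the group on the amide-type nitrogen, and none of them moved the number beyond the scatter, so the same kind of exchange is not expected to produce a step beyond the scatter in this assay either. Compound 4 is therefore estimated at 1900 nM, with a range from 900 nM to 4000 nM, which corresponds to an expected step of a 1.3-fold lower number from compound 3 to compound 4 (0.12 log units; within the scatter).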

Compound 4, half-maximal inhibitory concentration: 1600 nM
The estimate for compound 4 lay 1.2-fold (0.07 log units) above the measured number; the measured number falls inside the stated range.
By their numbers in this assay, from the lowest: compounds 4, 1, 2 and 3 (each within the scatter of the next).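

In this assay, the new steps are a 1.6-fold lower number from compound 3 to compound 4 (0.19 log units; within the scatter), a 1.2-fold lower number from compound 2 to compound 4 (0.07 log units; within the scatter) and a 1.1-fold lower number from compound 1 to compound 4 (0.03 log units; within the scatter), so compound 4 stays within the scatter of all three earlier compounds. Four different substituted phenyl groups on the amide-type nitrogen, now including a lone fluoro group, therefore give numbers that cannot be told apart. Nothing available explains why this position tolerates these exchanges.

As far as these compounds go, all four groups are phenyl rings, so it remains open whether a saturated ring, an amine, a carboxylic acid or a longer chain on this nitrogen would give a step beyond the scatter.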